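Swapping Bromo for Vinyloxy on a Shared Core

This account rests on a few compounds, and the source may have more. Where it says the series, first, only, none or still open, it means among the compounds named here.

In an assay on CHO cells with Alpha-2B adrenergic receptor (Homo sapiens) as the target (on this read-out higher numbers stand for larger maximal responses and lower numbers for smaller maximal responses), compound 1 `C=CCc1cccc(CC=C)c1OC(C)C1=NCCN1` gives 0.65, compound 2 `CC(Oc1ccccc1Br)C1=NCCN1` gives 0.4, and compound 3 `CC(Oc1ccccc1S(C)(=O)=O)C1=NCCN1` gives 0.45. Compound 2 thus stands lowest of the three: compound 3 lies close to it, while compound 1 lies further off. Compound 4 `C=COc1ccccc1OC(C)C1=NCCN1` has not been measured; it differs from compound 2 by vinyloxy in place of bromo on an aromatic carbon. Going by the values given here, only one measured step bears on this change, and it replaces the same bromo at the same place: a number 0.050 higher from compound 2 to compound 3 (within the scatter). That step stayed within the scatter, so another replacement of the bromo there is expected to shift the maximal response little, giving an estimated step of a number 0.050 higher from compound 2 to compound 4 (within the scatter). Compound 4 is therefore estimated at 0.45, with a range from 0.3 to 0.6.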

Compound 4, intrinsic activity: the largest response reached, as a fraction of the reference agonist's: 0.45
Beside the measured number, compound 4's estimate shows no gap at the digits printed; the range from low to high includes it.
By their numbers in this assay, from the lowest: compounds 2, 3 and 4 (each within the scatter of the next); then compound 1.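

In this assay, a second, different group has now replaced the bromo on this aromatic carbon, with vinyloxy giving a number 0.050 higher from compound 2 to compound 4 (within the scatter). Vinyloxy and methylsulfonyl also read alike, with no change at the digits printed from compound 3 to compound 4 (within the scatter), so neither replacement has moved the maximal response beyond the scatter. Nothing available explains why these replacements leave the response so little changed. From the compounds shown here alone, whether an amine or a carboxylic acid on this carbon would also stay this close remains open. So does whether a longer chain in place of the bromo would do the same.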